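The source may hold more compounds than are shown below. What is called first, only, known or untested is meant among the compounds shown, and "the series" means these compounds.

Working notes on the series, tested in a functional assay on PC-3 cells (Homo sapiens) for cytotoxicity, read by sulforhodamine B assay; a lower number here means a stronger inhibitor, a higher number a weaker inhibitor. Compound 1 `[N-]=[N+]=N[C@@H]1C(n2cc(Cl)c(=O)[nH]c2=O)[Se][C@H](CO)[C@H]1O` is the chloro member of the shared core; in this assay compound 1 gives only a limit, > 100000 nM. Compound 2 `[N-]=[N+]=N[C@@H]1C(n2cc(Br)c(=O)[nH]c2=O)[Se][C@H](CO)[C@H]1O` is its bromo counterpart; in this assay compound 2 likewise returns only a limit, > 100000 nM. Among the compounds with values here, the one measured step, a step that the two limits leave unreadable from compound 1 to compound 2, therefore cannot be sized, as the limit of > 100000 nM in this assay, at which 2 of the 2 values shown sit, records. On the numbers shown, compound 2 stands at the limit of this assay, with no readable distance to compound 1.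

Compound 3 `[N-]=[N+]=N[C@@H]1C(n2cc(I)c(=O)[nH]c2=O)[Se][C@H](CO)[C@H]1O` is the next halogen variant; its change from compound 2 is iodo in place of bromo on an aromatic carbon. Within the data shown here, the only measured step that bears on this change is the chloro-to-bromo step, which gives neither size nor direction, so no step beyond the scatter can be expected in this assay. Among the measured compounds shown here, compound 3 is accordingly expected to remain at the limit, with a step that the limit leaves unreadable from compound 2 to compound 3 estimated as no step. Compound 3 is estimated at 150000 nM, in the range 30000 nM to 600000 nM, most likely reported again as a limit.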

Compound 3, half-maximal inhibitory concentration: > 100000 nM
Compound 3: only a limit was reported; the forecaster's own chance of this, stated with the estimate: 85%; the middle value does not contradict the limit.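

Within the data shown here, no step among compound 1, compound 2 and compound 3 can be read in this assay, as all three return only a limit: the limit of > 100000 nM in this assay, at which 3 of the 3 values shown sit. The compounds shown leave open whether the chloro, bromo and iodo members differ at all in this assay, and which change to the shared core would give a readable value.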